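Swapping One Ether Side Chain for Another

A few compounds are considered here, and "the series" means these few. Any claim that something is new, unique, unknown or untested is made for them only; others in the source may bear on it.

Of the compounds shown here, three that share one core have been measured in an assay on cells for inhibition of cytochrome P450 11B1, mitochondrial (Homo sapiens); on this read-out higher numbers stand for weaker inhibition and lower numbers for stronger inhibition. Compound 1 `CC(C)CC1n2cncc2CN(Cc2ccc(OC(F)(F)F)cc2)S1(=O)=O` gives 544 nM. Compound 2 `C[C@@H](c1ccc(Cl)cc1)N1Cc2cncn2C(CC2(C)COC2)S1(=O)=O` gives 340 nM in this assay. Compound 3 `CC(C)OCC1n2cncc2CN([C@@H](C)c2ccc(Cl)cc2)S1(=O)=O` gives 222 nM in this assay, the lowest of the three numbers; compound 2 lies nearest to it, within the scatter, while compound 1 sits further away, beyond the scatter.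

Compound 4 `COC(C)(C)CC1n2cncc2CN([C@@H](C)c2ccc(Cl)cc2)S1(=O)=O` has not yet been measured. It differs from compound 3 in one place: 1-methoxy-1-methylethyl in place of isopropoxy on a saturated chain carbon bound to a saturated ring carbon. Seen one bond further out, the same difference reads isopropoxymethyl to 2-methoxy-2-methylpropyl.

Among the compounds with values here, only one measured step bears on this change, the one made at the same spot: a 1.5-fold lower number from compound 2 to compound 3 (0.19 log units; within the scatter). That step also exchanged one side chain for another on a saturated chain carbon bound to a saturated ring carbon, and the number moved by less than the scatter. With a single comparison of this kind at hand, the expectation for compound 4 is no step beyond the scatter in either direction, and a 1.1-fold higher number from compound 3 to compound 4 (0.05 log units; within the scatter) is the change expected. Compound 4 is therefore estimated at 250 nM in this assay, with a range from 110 nM to 600 nM.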

Compound 4, half-maximal inhibitory concentration: 20.6 nM
Beside the measured number, compound 4's estimate is 12-fold (1.08 log units) above it; measured number outside the range, below it.
By their numbers in this assay, from the lowest: compound 4; then compounds 3, 2 and 1 (each within the scatter of the next, the first and the last beyond it).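

At this position, on a saturated chain carbon bound to a saturated ring carbon, the choice of side chain can matter far more in this assay than the earlier swap suggested, since that swap stayed within the scatter: 1-methoxy-1-methylethyl in place of isopropoxy gives a large step (an 11-fold lower number from compound 3 to compound 4 (1.03 log units; beyond the scatter)), and 1-methoxy-1-methylethyl in place of 3-methyloxetan-3-yl gives another (a 17-fold lower number from compound 2 to compound 4 (1.22 log units; beyond the scatter)). The first of these changes is small on paper, as the entering group has one more carbon than the leaving one, and both groups have one hydrogen-bond acceptor, no ring and no net charge, so a slight change in composition can go with a large change in the number. Within the data shown here, nothing measured so far accounts for the size of these steps.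

On these data alone, it remains open whether a side chain with no oxygen, such as a plain longer carbon chain, or one carrying an amine would give a number as low as that of compound 4. As far as these compounds go, it is also open whether 1-methoxy-1-methylethyl would give a step of this size alongside the other substituent found in compound 1.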